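The source may report more compounds than this note shows. Statements on the series, on what has been measured and on what is new or still open speak of the compounds shown alone.

In a functional assay on MCF7 cells (Homo sapiens) for cytotoxicity, read by MTT assay, with a stated time of 24 h (on this read-out higher numbers stand for weaker inhibition and lower numbers for stronger inhibition), compound 1 (`C/C(=N\NC(=O)/C(C#N)=C/c1ccccc1)c1c(O)c2ccc(O)cc2oc1=O`) gives 19200 nM and compound 2 (`COc1cc(/C=C(\C#N)C(=O)N/N=C(\C)c2c(O)c3ccc(O)cc3oc2=O)ccc1O`) gives 13700 nM in the same test. These two numbers lie within the usual scatter of each other, so compound 2 stands level with compound 1. Compound 3 (`COc1ccc(/C=C(\C#N)C(=O)N/N=C(\C)c2c(O)c3ccc(O)cc3oc2=O)cc1`) has not yet been measured. Its structure departs from compound 2 in one place, on a double-bonded chain carbon bound to a double-bonded chain carbon (4-methoxyphenyl in place of 4-hydroxy-3-methoxyphenyl on a double-bonded chain carbon bound to a double-bonded chain carbon), where 4-methoxyphenyl takes the place of 4-hydroxy-3-methoxyphenyl. For the measured compounds named here, the only measured step at that place is a 1.4-fold lower number from compound 1 to compound 2 (0.15 log units; within the scatter) and it stays within the scatter. With a single small step as the guide, no step beyond the scatter is expected in this assay and the estimated step is a 1.1-fold higher number from compound 2 to compound 3 (0.04 log units; within the scatter) in size. The expected value for compound 3 is 15000 nM with an estimated range from 7000 nM to 32000 nM around it.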

Compound 3, half-maximal inhibitory concentration: 8940 nM
Estimate against measurement, compound 3: 1.7-fold (0.22 log units) above; the range from low to high includes it.
By their numbers in this assay, from the lowest: compounds 3, 2 and 1 (each within the scatter of the next, the first and the last beyond it).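

In this assay, 4-methoxyphenyl in place of 4-hydroxy-3-methoxyphenyl gives a 1.5-fold lower number from compound 2 to compound 3 (0.19 log units; within the scatter), so the hydroxy group can go from this ring without a change that clears the scatter. For the compounds shown here, the new finding is that one methoxy on the phenyl ring gives the first step at this place beyond the scatter, a 2.1-fold lower number from compound 1 to compound 3 (0.33 log units; beyond the scatter), although this step is modest and rests on a single pair, while compound 2, which carries both methoxy and hydroxy, stays within the scatter of compound 1. No outside evidence bears on what lies behind these numbers.

From the compounds shown here alone, it remains open whether an amine, a chlorine atom or a longer ethoxy chain on this ring would move the number further. Going by these compounds, it is also open whether a larger step can be reached at this place at all.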